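The source may report more compounds than this note shows. Statements on the series, on what has been measured and on what is new or still open speak of the compounds shown alone.

Measured compounds:
- compound 1 `CN(C(=O)NC(=O)c1ccc(F)c(F)c1)c1nc(C(F)(F)F)c(C(=O)N/N=C/c2ccc(C(F)(F)F)cc2)s1`: 5.93 ug/mL
- compound 2 `CN(C(=O)NC(=O)c1ccc(F)c(F)c1)c1nc(C(F)(F)F)c(C(=O)N/N=C/c2ccccc2C(F)(F)F)s1`: 8.21 ug/mL
- compound 3 `CN(C(=O)NC(=O)c1ccc(Cl)cc1Cl)c1nc(C(F)(F)F)c(C(=O)N/N=C/c2cc(C(F)(F)F)cc(C(F)(F)F)c2)s1`: a limit, > 100 ug/mL

In a functional assay on MCF7 cells (Homo sapiens) for inhibition, read by MTT assay, with a stated time of 72 h (on this read-out lower numbers stand for stronger inhibition and higher numbers for weaker inhibition), compound 1 gives 5.93 ug/mL, the lowest of the two numbers obtained. Compound 2 gives 8.21 ug/mL in this assay, and the step of a 1.4-fold higher number from compound 1 to compound 2 (0.14 log units; within the scatter) changes only the aryl group on the carbon carrying a double bond to nitrogen. For compound 3 this assay returns only a limit, > 100 ug/mL, which is the limit described as the limit of > 100 ug/mL in this assay, at which 1 of the 3 values shown sits; compound 3 differs from compound 1 in two places at once, so no single step can be read from it.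

Compound 4 `CN(C(=O)NC(=O)c1ccc(C(F)(F)F)cc1)c1nc(C(F)(F)F)c(C(=O)N/N=C/c2ccc(C(F)(F)F)cc2)s1` has not yet been measured. It differs from compound 1 in one place: 4-(trifluoromethyl)phenyl in place of 3,4-difluorophenyl on a carbonyl carbon. Among the measured compounds shown here, none of the measured steps touches this carbonyl-bound aryl group. For the measured compounds named here, the only single step available, from compound 1 to compound 2, lies within the scatter and concerns the other end of the shared core. Going by the values given here, with no step informing this position, no change beyond the scatter is expected, and the estimate carries a wide range. Compound 4 is therefore expected to give 7 ug/mL in this assay, between 2.5 ug/mL and 25 ug/mL, a step of a 1.2-fold higher number from compound 1 to compound 4 (0.07 log units; within the scatter).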

Compound 4, half-maximal inhibitory concentration: > 100 ug/mL
Compound 4: a limit, no number; the forecaster's own chance of this, stated with the estimate: 15%; at least 14-fold (1.15 log units) between middle value and limit.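

Among the compounds shown here, the aryl group on the carbonyl carbon, which no earlier step touched, turns out to matter a great deal in this assay: 4-(trifluoromethyl)phenyl in place of 3,4-difluorophenyl gives an at least 16-fold higher number from compound 1 to compound 4 (1.22 log units; beyond the scatter). Compound 4 gives > 100 ug/mL, which is a limit of the assay and not a number, so this step has a known minimum but no known full size. This end of the molecule therefore tolerates far less change than the earlier step at the other end of the shared core suggested, and the new value is not an isolated one in this small set: the limit of > 100 ug/mL in this assay, at which 2 of the 4 values shown sit.

What the compounds shown leave open is which part of the change counts, the loss of the two fluorines or the arrival of the trifluoromethyl group, since a single swap does both at once. A plain phenyl on the same carbonyl carbon, or a phenyl carrying a single fluorine, a methoxy group or an amine, would help separate these two readings and show how narrow the tolerance at this position really is.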